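The source may report more compounds than this note shows. Statements on the series, on what has been measured and on what is new or still open speak of the compounds shown alone.

Measured so far:
- compound 1 `CC(=O)Nc1ccc(S(=O)(=O)NNC(=O)c2cccnc2Nc2ccc(Cl)cc2)cc1`: > 100000 nM
- compound 2 `O=C(NNS(=O)(=O)c1ccc(F)cc1)c1cccnc1Nc1ccc(Cl)cc1Cl`: 52500 nM

Compound 1 is known in a functional assay on UACC-257 cells (Homo sapiens) for antiproliferative activity (a lower number here means a stronger inhibitor of growth, a higher number a weaker inhibitor of growth), only as a limit. The value > 100000 nM for compound 1 is a limit of the assay and not a number, as marked by the limit of > 100000 nM in this assay, at which 1 of the 2 values shown sits. Among the compounds with values here, compound 2 differs from compound 1 in more than one place, so no single step between them is defined; in this assay compound 2 gives 52500 nM, a number inside the measured range.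

The next compound is compound 3 `O=C(NNS(=O)(=O)c1ccc(Cl)cc1Cl)c1cccnc1Nc1ccc(Cl)cc1`. Relative to compound 1 the change is 2,4-dichlorophenyl in place of 4-acetamidophenyl on a sulfonyl sulfur. The core and the anilino side are kept; only the aryl group on the sulfonyl sulfur is exchanged.

Within the data shown here, no measured step covers this exchange. Since compound 1 sits at the limit, a step can only be registered toward lower numbers; the expected step is an at least 2.5-fold lower number from compound 1 to compound 3 (0.39 log units; beyond the scatter), modest but beyond the scatter, with a real chance that compound 3 again returns only a limit. For compound 3 the estimate in this assay is 40000 nM, within 10000 nM to 150000 nM.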

Compound 3, concentration for total growth inhibition: 60300 nM
Beside the measured number, compound 3's estimate is 1.5-fold (0.18 log units) below it; measured number inside the range.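

In this assay compound 3 gives 60300 nM, a number inside the measured range, which shows what a change confined to the aryl group on the sulfonyl sulfur, with the core and the anilino side kept, can bring in this series. Compound 1 gives > 100000 nM, which is a limit of the assay and not a number: the limit of > 100000 nM in this assay, at which 1 of the 3 values shown sits. The size of the exchange is therefore known only as a floor, an at least 1.6-fold lower number from compound 1 to compound 3 (0.21 log units; that floor lies within the scatter), so the pair establishes no gain beyond the scatter, although the true step may be larger.

From the compounds shown here alone, it remains open whether the shift in the number goes with the loss of the acetamido group or with the entry of the chlorine atoms, a separation that an unsubstituted phenyl or a 4-chlorophenyl on the sulfonyl sulfur could provide. Also open, going by these compounds, is whether an amine or a carboxylic acid on this aryl ring, or a simple methyl in its place, would give a stronger inhibitor of growth than compound 3.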